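Working notes: fluoro in place of methyl

The source may report more compounds than this note shows. Statements on the series, on what has been measured and on what is new or still open speak of the compounds shown alone.

In a functional assay on HeLa cells (Homo sapiens) for inhibition, read by MTT assay, with a stated time of 72 h (a lower number here means a stronger inhibitor, a higher number a weaker inhibitor), compound 1 `COc1ccc(-c2nnc(SCCCN3CCN(c4nc5ccccc5o4)CC3)o2)cc1` gives 210000 nM, compound 2 `Cc1ccc(-c2nnc(SCCCN3CCN(c4nc5ccccc5o4)CC3)o2)cc1` gives 133000 nM and compound 3 `Clc1ccc(-c2nnc(SCCCN3CCN(c4nc5ccccc5o4)CC3)o2)cc1` gives 101000 nM. Compound 2 holds the middle of these three numbers, within the scatter of both others. Compound 4 `Fc1ccc(-c2nnc(SCCCN3CCN(c4nc5ccccc5o4)CC3)o2)cc1` differs from compound 2 by fluoro in place of methyl on an aromatic carbon, para to a large group. The relevant measured changes at this place are a 1.3-fold lower number from compound 2 to compound 3 (0.12 log units; within the scatter) and a 1.6-fold lower number from compound 1 to compound 2 (0.20 log units; within the scatter), both within the scatter, and a 2.1-fold lower number from compound 1 to compound 3 (0.32 log units; beyond the scatter), a modest step beyond it. No step beyond the scatter is therefore expected in this assay. The expected step is a 1.1-fold lower number from compound 2 to compound 4 (0.04 log units; within the scatter). Compound 4 is estimated at 120000 nM, with an expected range of 70000 nM to 200000 nM.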

Compound 4, half-maximal inhibitory concentration: 196000 nM
The estimate for compound 4 lay 1.6-fold (0.21 log units) below the measured number; the measured number falls inside the stated range.
By their numbers in this assay, from the lowest: compounds 3, 2, 4 and 1 (each within the scatter of the next, the first and the last beyond it).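

In this assay the 4-methylphenyl to 4-fluorophenyl change gives a 1.5-fold higher number from compound 2 to compound 4 (0.17 log units; within the scatter) and so does not separate these two compounds. Compound 4 also stays within the scatter of both the chloro and the methoxy compound, with a 1.9-fold higher number from compound 3 to compound 4 (0.29 log units; within the scatter) and a 1.1-fold lower number from compound 1 to compound 4 (0.03 log units; within the scatter), leaving the step from compound 1 to compound 3 as the only one beyond the scatter at this position. No supporting measurement bears on this result. Going by these compounds, whether an amine, a carboxylic acid or a longer chain at this place would give a larger step remains open.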